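The source may hold more compounds than are shown below. What is called first, only, known or untested is meant among the compounds shown, and "the series" means these compounds.

Compounds measured so far:

Compound 1, `CC1=CC[C@H](C(C)(C)NC(=S)N/N=C/c2ccccc2)CC1`: in a functional assay on NCI/ADR-RES cells (Homo sapiens) for inhibition, read by sulforhodamine B assay, with a stated time of 48 h (a higher number here means a weaker inhibitor of growth, a lower number a stronger inhibitor of growth), compound 1 gives only the limit > 100000 nM.
Compound 2, `CC1=CC[C@H](C(C)(C)NC(=S)N/N=C/c2ccc(O)cc2)CC1`: in this assay compound 2 gives only the limit > 100000 nM.
Compound 3, `CC1=CC[C@H](C(C)(C)NC(=S)N/N=C/c2cccc(Cl)c2)CC1`: in this assay compound 3 gives only the limit > 100000 nM.

Compound 3 therefore stands exactly where its two companions stand: every one of the three values is a limit of the assay, with all of them sitting at the limit of > 100000 nM in this assay, at which 3 of the 3 values shown sit. None of the three is a number, so nothing can be said about order among them.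

Compound 4 is `CC1=CC[C@H](C(C)(C)NC(=S)N/N=C/c2cccc([N+](=O)[O-])c2)CC1`, and it differs from compound 3 by nitro in place of chloro on an aromatic carbon. Three measured steps might bear on this change, but each of them ends at a limit on both sides: a step that the two limits leave unreadable from compound 1 to compound 3, a step that the two limits leave unreadable from compound 1 to compound 2 and a step that the two limits leave unreadable from compound 2 to compound 3. Their sizes cannot be read, so they give no direction and no magnitude; all they show is that neither a hydroxy nor a chloro on the aromatic ring brought a compound off the limit.

On that basis compound 4 is expected to stay at the limit as well, so the step of a number no higher from compound 3 to compound 4 (the limit leaves the size open) is expected to be too small to read. The estimate for compound 4 in this assay is 100000 nM, with a range from 30000 nM to 300000 nM.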

Compound 4, concentration for total growth inhibition: > 100000 nM
Compound 4: a limit, no number (the forecaster's own chance of this, stated with the estimate: 80%); the middle value lies on the limit itself.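

In this assay compound 4 gives > 100000 nM as a limit and not a number. The steps to compound 4 from compound 3 and from compound 1 therefore cannot be read. The compounds shown leave open how strongly any of them inhibits growth, and whether any ring substituent would bring a compound off this shared limit: the limit of > 100000 nM in this assay, at which 4 of the 4 values shown sit.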